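The compounds below may be only part of what the source reports. "The series", "measured", "known", "first", "only" and "open" are said of these compounds alone.

Compound 1 `CC(C)c1cccc(C(C)C)c1NC(=O)Nc1nc2ccccc2n1-c1ccccc1Br`: 22 nM
Compound 2 `CC(C)c1cccc(C(C)C)c1NC(=O)Nc1nc2ccccc2n1-c1ccccc1C(F)(F)F`: 72 nM

Within the data shown here, in an assay on isolated protein for displacement of a labelled ligand from acyl-CoA:cholesterol acyltransferase (Oryctolagus cuniculus) (on this read-out higher numbers stand for weaker inhibition and lower numbers for stronger inhibition), compound 1 gives 22 nM and holds the lowest of the two numbers measured so far. Its nearest neighbour is compound 2, which gives 72 nM; this is a 3.3-fold higher number from compound 1 to compound 2 (0.51 log units; beyond the scatter). Compound 3 `CC(C)c1cccc(C(C)C)c1NC(=O)Nc1nc2ccccc2n1-c1ncccc1Cl` has not yet been measured. It differs from compound 1 in one place: 3-chloropyridin-2-yl in place of 2-bromophenyl on an aromatic nitrogen. Among the measured compounds shown here, the only measured step on this part of the shared core is the one from compound 1 to compound 2, where bromo gave way to trifluoromethyl on the same one six-membered aromatic ring of carbon only, and the number rose modestly. For the measured compounds named here, for compound 3 the ring itself changes to one six-membered aromatic ring with 1 hetero atom and bromo gives way to chloro, which no measured pair mirrors. A modest rise is therefore expected, a 2.0-fold higher number from compound 1 to compound 3 (0.31 log units; beyond the scatter), and compound 3 is estimated at 45 nM within 15 nM to 140 nM.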

Compound 3, half-maximal inhibitory concentration: 100 nM
The estimate for compound 3 lay 2.2-fold (0.35 log units) below the measured number; the range from low to high includes it.
By their numbers in this assay, from the lowest: compound 1; then compounds 2 and 3 (each within the scatter of the next).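

In this assay, 3-chloropyridin-2-yl on this aromatic nitrogen gives a 4.5-fold higher number from compound 1 to compound 3 (0.66 log units; beyond the scatter) and so does not hold the number of the 2-bromophenyl compound. Against the 2-(trifluoromethyl)phenyl group, the same change gives a 1.4-fold higher number from compound 2 to compound 3 (0.14 log units; within the scatter) and leaves these two different groups level, so among these three compounds only the 2-bromophenyl group of compound 1 stands apart with a lower number. Nothing available here accounts for this difference.

Compound 3 changes the ring and swaps bromo for chloro in one step, so the compounds shown leave open how much of the rise belongs to the ring nitrogen and how much to the halogen. A 2-chlorophenyl or a 3-bromopyridin-2-yl group in this place would separate the two changes.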